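Amide substituent variation on the shared core

A few compounds are considered here, and "the series" means these few. Any claim that something is new, unique, unknown or untested is made for them only; others in the source may bear on it.

The shared core carries an amide whose substituent on the carbonyl carbon is varied. Compound 1 `O=C(Nc1cccc(Nc2ncc(F)c(Nc3ccc(F)cc3)n2)c1)c1ccccc1` bears phenyl there; in a functional assay on DU-145 cells (Homo sapiens) for antiproliferative activity, read by sulforhodamine B assay, with a stated time of 3 days (a higher number here means a weaker inhibitor of growth, a lower number a stronger inhibitor of growth), compound 1 gives > 10000 nM, which is a limit of the assay and not a number. Compound 2 `O=C(Nc1cccc(Nc2ncc(F)c(Nc3ccc(F)cc3)n2)c1)c1cnccn1` carries pyrazin-2-yl, and in this assay compound 2 gives 26400 nM. Compound 3 `COCC(=O)Nc1cccc(Nc2ncc(F)c(Nc3ccc(F)cc3)n2)c1` carries methoxymethyl, and in this assay compound 3 gives 4460 nM, the lowest of the two numbers shown, with compound 2 nearest. The steps read an at least 2.2-fold lower number from compound 1 to compound 3 (0.35 log units; beyond the scatter) and a 5.9-fold lower number from compound 2 to compound 3 (0.77 log units; beyond the scatter); the remaining step is a step that the limit leaves unreadable from compound 1 to compound 2.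

Compound 4 `O=C(Nc1cccc(Nc2ncc(F)c(Nc3ccc(F)cc3)n2)c1)c1cccc([N+](=O)[O-])c1` is not yet measured. It differs from compound 3 in this way: 3-nitrophenyl in place of methoxymethyl on a carbonyl carbon. Both measured steps onto methoxymethyl lowered the number, and compound 4 moves back to an aromatic ring on the carbonyl carbon, so a higher number is expected, with the limit of > 10000 nM in this assay, at which 1 of the 3 values shown sits, seen for compound 1 a real possibility for compound 4 as well. The expected step is a 4.5-fold higher number from compound 3 to compound 4 (0.65 log units; beyond the scatter). Compound 4 is estimated at 20000 nM, between 6000 nM and 60000 nM.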

Compound 4, concentration for 50% growth inhibition: 12600 nM
Compound 4: middle estimate off by 1.6-fold (0.20 log units), on the high side; the measured number falls inside the stated range.
By their numbers in this assay, from the lowest: compound 3; then compound 4; then compound 2.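

In this assay, methoxymethyl on the carbonyl carbon still gives the lowest number, with a 2.8-fold higher number from compound 3 to compound 4 (0.45 log units; beyond the scatter), so an aromatic ring there now gives a readable number that stays on the higher side. The ring itself also counts, with a 2.1-fold lower number from compound 2 to compound 4 (0.32 log units; beyond the scatter), a modest step that places 3-nitrophenyl on the lower side of pyrazin-2-yl. The effect of the nitro group on the phenyl ring cannot be read, because compound 1 stands at a limit and not at a number: the limit of > 10000 nM in this assay, at which 1 of the 4 values shown sits.

On these data alone, it remains open whether the lower number belongs to methoxymethyl alone or extends to non-aromatic groups generally, such as a longer ether chain, a dimethylaminomethyl group or a cyclohexyl ring on the carbonyl carbon. Also open, as far as these compounds go, is how a 4-nitrophenyl or 3-aminophenyl group would compare with 3-nitrophenyl.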